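An Amine in Place of a Sulfonate Ester

The source may report more compounds than this note shows. Statements on the series, on what has been measured and on what is new or still open speak of the compounds shown alone.

Measured so far in a functional assay on MDA-MB-435 cells (Homo sapiens) for cytotoxicity, read by MTT assay, with a stated time of 72 h; a lower number here means a stronger inhibitor, a higher number a weaker inhibitor:
Compound 1 `N[C@H]1CC[C@H](Nc2c(C(=O)NCc3ccc(Cl)cc3)nc(Br)c3cccnc23)CC1` gives 1000 nM.
Compound 2 `CS(=O)(=O)Oc1c(C(=O)NCc2ccc(F)cc2)nc(Br)c2cccnc12` reaches only a limit of the assay, > 20000 nM.
Compound 3 `CS(=O)(=O)NCCCCCCN(c1nc(C(=O)NCc2ccc(F)cc2)c(O)c2ncccc12)S(C)(=O)=O` gives 20000 nM.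

Compound 2 stands at the weak end of what has been seen: it returns no number, only the limit, (the limit of > 20000 nM in this assay, at which 1 of the 3 values shown sits). Compound 1 and compound 3 both give numbers, and of those two, compound 1 is the stronger inhibitor. Compound 4 `C[C@H](Nc1c(C(=O)NCc2ccc(F)cc2)nc(Br)c2cccnc12)c1ccccc1` has not yet been measured. It differs from compound 2 in one place: (1-phenylethyl)amino in place of (methylsulfonyl)oxy on an aromatic carbon. Among the measured compounds shown here, compound 1, the only measured compound whose core carries a nitrogen-linked substituent in place of a sulfonate ester, gives 1000 nM, and that is the nearest guide to what an amino substituent at this site may do. Compound 4 is therefore expected to move away from the limit toward stronger inhibition, a step in this assay estimated as an at least 6.6-fold lower number from compound 2 to compound 4 (0.82 log units; beyond the scatter), beyond the usual scatter. Compound 4 is expected to give about 3000 nM, within a range from 800 nM to 15000 nM.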

Compound 4, half-maximal inhibitory concentration: > 20000 nM
Compound 4 was reported as a limit; the forecaster's own chance of this, stated with the estimate: 20%; at least 6.6-fold (0.82 log units) between middle value and limit.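

In this assay compound 4 gives > 20000 nM, a limit of the assay and not a number. Among the compounds shown here, compound 2 also stands at a limit, > 20000 nM, so no step from compound 2 to compound 4 can be read. The compounds shown leave open whether (1-phenylethyl)amino in place of (methylsulfonyl)oxy on the shared core changes inhibition at all.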